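Benzyl ether variation on the diaryl ether amine core

A few compounds are considered here, and "the series" means these few. Any claim that something is new, unique, unknown or untested is made for them only; others in the source may bear on it.

In a functional assay on PC-3 cells (Homo sapiens) for cytotoxicity, read by sulforhodamine B assay (a lower number here means a stronger inhibitor of growth, a higher number a weaker inhibitor of growth), compound 1 `COc1cccc(OC)c1OCCNCCOc1ccccc1OCc1ccc(Cl)cc1` gives 2400 nM and compound 2 `COc1cccc(OC)c1OCCNCCOc1ccccc1OCc1ccc(C)cc1` gives 7800 nM. Within the data shown here, compound 2 is the higher of the two numbers, and the only measured step is a 3.3-fold higher number from compound 1 to compound 2 (0.51 log units; beyond the scatter). Compound 3 `COc1cccc(COc2ccccc2OCCNCCOc2c(OC)cccc2OC)c1` differs from compound 2 by 3-methoxyphenyl in place of 4-methylphenyl on a saturated chain carbon bound to an oxygen on an aromatic ring. Among the measured compounds shown here, no measured step covers a methoxy on this ring; the step between compound 1 and compound 2 shows only that a change on this ring can move the number beyond the scatter. For compound 3 the expected step is a 1.3-fold lower number from compound 2 to compound 3 (0.11 log units; within the scatter), with no direction beyond the scatter assured. The estimate for compound 3 is 6000 nM, range 2500 nM to 15000 nM.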

Compound 3, concentration for 50% growth inhibition: 2500 nM
For compound 3 the middle estimate is 2.4-fold (0.38 log units) above the measured one; measured number inside the range.
By their numbers in this assay, from the lowest: compounds 1 and 3 (each within the scatter of the next); then compound 2.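

Working from this assay, 3-methoxyphenyl in place of 4-methylphenyl on a saturated chain carbon bound to an oxygen on an aromatic ring gives a 3.1-fold lower number from compound 2 to compound 3 (0.49 log units; beyond the scatter), so the number at this place can also be moved by a change of group that is not a swap of chloro for methyl. Against the 4-chlorophenyl, the same group gives a 1.0-fold higher number from compound 1 to compound 3 (0.02 log units; within the scatter), which leaves two different substituted rings on level terms. No evidence bears on the reason for either step.

From the compounds shown here alone, compound 3 changes the group and its place on the ring together, so the share of each stays open. Also open, going by these compounds, is how an unsubstituted phenyl, or a ring carrying an amine or a carboxylic acid, would read here.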